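Methoxy on the ring: a second position, same question

The compounds below may be only part of what the source reports. "The series", "measured", "known", "first", "only" and "open" are said of these compounds alone.

Compound 2 `CC(C)(C)OC(=O)/C=C1/C(=O)Nc2ccccc21`: 2450 nM; compound 1 `CCOC(=O)/C=C1/C(=O)Nc2ccccc21`: 4830 nM; compound 3 `COc1ccc2c(c1)/C(=C\C(=O)OC(C)(C)C)C(=O)N2`: 6190 nM.

These three numbers come from a functional assay on HL-60 cells (Homo sapiens) for cytotoxicity, read by CCK-8 assay, with a stated time of 72 h; a lower number here means a stronger inhibitor, a higher number a weaker inhibitor. Compound 2 holds the lowest number, but the gap to compound 1 is within the scatter, a 2.0-fold lower number from compound 1 to compound 2 (0.29 log units; within the scatter), whereas the gap to compound 3 is beyond it, a 2.5-fold higher number from compound 2 to compound 3 (0.40 log units; beyond the scatter). Compound 4 `COc1ccc2c(c1)NC(=O)/C2=C/C(=O)OC(C)(C)C` differs from compound 2 by methoxy in place of hydrogen on an aromatic carbon. Compound 3 carries the same group on a different aromatic carbon of the same core, and that step weakened potency modestly. For the measured compounds named here, the one step that bears on the new change therefore points to a modest rise in the number, and a similar outcome is expected for compound 4, with a 1.8-fold higher number from compound 2 to compound 4 (0.26 log units; within the scatter), giving an estimated value of 4500 nM between 2000 nM and 10000 nM.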

Compound 4, half-maximal inhibitory concentration: 9150 nM
Estimate against measurement, compound 4: 2.0-fold (0.31 log units) below; low and high end bracket the measured number.
By their numbers in this assay, from the lowest: compounds 2, 1, 3 and 4 (each within the scatter of the next, the first and the last beyond it).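

Methoxy in place of hydrogen on this aromatic carbon weakens compound 4 by a clear margin (a 3.7-fold higher number from compound 2 to compound 4 (0.57 log units; beyond the scatter)). Compound 3 also loses potency with methoxy on a different aromatic carbon (a 2.5-fold higher number from compound 2 to compound 3 (0.40 log units; beyond the scatter)), so the group raises the number at both carbons shown, and compound 3 and compound 4 lie within the scatter of each other. No measurement here accounts for this rise. Still open, from the compounds shown here alone, is whether a hydroxy group, fluorine or an amine on this carbon would keep the number near that of compound 2. Methoxy on the other ring carbons also remains open.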